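Furan-2-yl to thiophen-3-yl: working notes

A few compounds are considered here, and "the series" means these few. Any claim that something is new, unique, unknown or untested is made for them only; others in the source may bear on it.

In a functional assay on HeLa S3 cells (Homo sapiens) for antiproliferative activity, read by XTT assay, with a stated time of 72 h (a higher number here means a weaker inhibitor, a lower number a stronger inhibitor), compound 3 `CNc1ncnc2c1c(-c1ccco1)cn2[C@@H]1O[C@H](CO)[C@@H](O)[C@H]1O` gives 5000 nM. Compound 2 `CSc1ncnc2c1c(-c1cccs1)cn2[C@@H]1O[C@H](CO)[C@@H](O)[C@H]1O` gives 1960 nM, so compound 3 holds the higher of the two numbers, and the gap lies beyond the usual scatter. Compound 1 `COc1ncnc2c1c(-c1ccccc1)cn2[C@@H]1O[C@H](CO)[C@@H](O)[C@H]1O` returns only a limit in this assay, > 20000 nM. Within the data shown here, no two measured compounds differ in one place only, so no direct step is available as a guide.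

Compound 4 `CNc1ncnc2c1c(-c1ccsc1)cn2[C@@H]1O[C@H](CO)[C@@H](O)[C@H]1O` has thiophen-3-yl in place of furan-2-yl on an aromatic carbon of a five-membered aromatic ring with 1 nitrogen, and it is otherwise unchanged from compound 3: thiophen-3-yl in place of furan-2-yl on an aromatic carbon. Compound 3 differs from compound 2 in more than one place, but compound 2 also carries a thiophene ring and gives 1960 nM. That single value gives weak support for a move towards a lower number. The expected step is a 1.4-fold lower number from compound 3 to compound 4 (0.15 log units; within the scatter), which is small and not expected to exceed the scatter. For compound 4 the estimated value is 3500 nM, with an expected range of 1000 nM to 12000 nM.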

Compound 4, half-maximal inhibitory concentration: > 20000 nM
Compound 4: no number, only a limit; the forecaster's own chance of this, stated with the estimate: 8%; middle value at least 5.7-fold (0.75 log units) away from the limit.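

In this assay, thiophen-3-yl is not interchangeable with furan-2-yl on this aromatic carbon, with an at least 4.0-fold higher number from compound 3 to compound 4 (0.60 log units; beyond the scatter). Compound 4 gives > 20000 nM, which is a limit and not a number, so only the minimum size of the step can be read. The two groups have the same counts of heavy atoms, hydrogen-bond donors and hydrogen-bond acceptors and carry no net charge, so these counts do not separate them, and the result ends at the assay limit: the limit of > 20000 nM in this assay, at which 2 of the 4 values shown sit.

As far as these compounds go, it remains open whether the step follows the change of hetero atom or its place in the ring. A thiophen-2-yl or furan-3-yl group on this carbon, with the rest of compound 3 unchanged, would separate these two readings.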